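Ethoxycarbonyl to methoxycarbonyl on two related cores

The source may hold more compounds than are shown below. What is called first, only, known or untested is meant among the compounds shown, and "the series" means these compounds.

Compound 1 `CCOC(=O)C1=C(C)NC(=O)NC1c1cccc([N+](=O)[O-])c1` gives 27.7 ug/mL in a functional assay, read by spectrophotometry, with a stated time of 2 h; a higher number here means a weaker inhibitor, a lower number a stronger inhibitor. Compound 3 `CCOC(=O)C1=C(C)NC(=O)NC1c1ccc([N+](=O)[O-])cc1` gives 33.3 ug/mL in this assay, and compound 2 `COC(=O)C1=C(C)NC(=O)NC1c1ccc([N+](=O)[O-])cc1` gives 27.8 ug/mL. All three numbers sit within the usual scatter of one another. The difference between the cores of compound 1 and compound 3 is not broken down here. Compound 2 differs from compound 3 by hydrogen in place of methyl on a saturated chain carbon bound to an oxygen next to a carbonyl group, and the measured step was a 1.2-fold lower number from compound 3 to compound 2 (0.08 log units; within the scatter). Compound 4 `COC(=O)C1=C(C)NC(=O)NC1c1cccc([N+](=O)[O-])c1` is not yet measured in this assay; it differs from compound 1 by hydrogen in place of methyl on a saturated chain carbon bound to an oxygen next to a carbonyl group, the same change at the same place. Compound 4 is expected to show the step of a 1.2-fold lower number from compound 1 to compound 4 (0.06 log units; within the scatter). That expectation rests on compound 2 and compound 3, whose step was a 1.2-fold lower number from compound 3 to compound 2 (0.08 log units; within the scatter), and on compound 1 giving 27.7 ug/mL. Compound 4 is estimated to give 24 ug/mL, within 15 ug/mL to 38 ug/mL.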

Compound 4, half-maximal inhibitory concentration: 27.1 ug/mL
The estimate for compound 4 lay 1.1-fold (0.05 log units) below the measured number; measured number inside the range.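

Ethoxycarbonyl to methoxycarbonyl on the core of compound 1 gives a 1.0-fold lower number from compound 1 to compound 4 (0.01 log units; within the scatter) in this assay. Set beside the earlier step, the change carries from one core to the other with no difference that can be told apart: the same change on two cores in this assay, a 1.2-fold lower number (0.08 log units; within the scatter) from compound 3 to compound 2 and a 1.0-fold lower number (0.01 log units; within the scatter) from compound 1 to compound 4, 1.2-fold (0.07 log units) apart, within the scatter of two such steps. This shows that the change stays within the scatter on both cores, but since neither step is beyond the scatter, it does not show how a step of clear size would carry over, and it says nothing about cores other than these two.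

The compounds shown leave open whether a longer chain such as propyl or butyl in place of ethyl would stay within the scatter. Also open, on these data alone, is what a carboxylic acid or a primary amide in place of the ethoxycarbonyl group would give.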